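The source may report more compounds than this note shows. Statements on the series, on what has been measured and on what is new or still open speak of the compounds shown alone.

Compound 1 `O=C(N/N=C/c1ccc(F)cc1)Nc1cc2c(Nc3ccc(F)c(Cl)c3)ncnc2cc1O[C@H]1CCOC1` gives 35100 nM in a functional assay on A549 cells (Homo sapiens) for cytotoxicity, read by MTT assay, with a stated time of 72 h (a higher number here means a weaker inhibitor, a lower number a stronger inhibitor), and compound 2 `COc1ccc(/C=N/NC(=O)Nc2cc3c(Nc4ccc(F)c(Cl)c4)ncnc3cc2O[C@H]2CCOC2)c(OC)c1OC` gives 25200 nM, the two sitting within the usual scatter of one another. For the measured compounds named here, the only change already measured at the carbon with a double bond to nitrogen, a 1.4-fold lower number from compound 1 to compound 2 (0.14 log units; within the scatter), stayed within that scatter. Compound 3 `CCN(CC)c1ccc(/C=N/NC(=O)Nc2cc3c(Nc4ccc(F)c(Cl)c4)ncnc3cc2O[C@H]2CCOC2)c(O)c1` differs from compound 1 at the same place: 4-(diethylamino)-2-hydroxyphenyl in place of 4-fluorophenyl on a carbon with a double bond to nitrogen. Going by the values given here, since the one comparable step stayed small, compound 3 is expected to show no shift beyond the scatter, a 1.2-fold lower number from compound 1 to compound 3 (0.07 log units; within the scatter). Compound 3 is therefore estimated at 30000 nM, in a range from 10000 nM to 90000 nM.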

Compound 3, half-maximal inhibitory concentration: 15700 nM
For compound 3 the middle estimate is 1.9-fold (0.28 log units) above the measured one, within the range that was stated.
By their numbers in this assay, from the lowest: compounds 3, 2 and 1 (each within the scatter of the next, the first and the last beyond it).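

On the carbon with a double bond to nitrogen, swapping the group can now move the number in this assay beyond the scatter: 4-(diethylamino)-2-hydroxyphenyl in place of 4-fluorophenyl gives a modest step (a 2.2-fold lower number from compound 1 to compound 3 (0.35 log units; beyond the scatter)). The same group in place of 2,3,4-trimethoxyphenyl stays within the scatter (a 1.6-fold lower number from compound 2 to compound 3 (0.21 log units; within the scatter)). Nothing available explains why these two steps differ in this way. Still open, as far as these compounds go, is whether the diethylamino part or the hydroxy part carries the step from compound 1 to compound 3. Also open, from the compounds shown here alone, is how a ring bearing a carboxylic acid or a longer alkyl chain would behave here.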